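The source may report more compounds than this note shows. Statements on the series, on what has been measured and on what is new or still open speak of the compounds shown alone.

Compound 1 `CCCC(C)C(=O)Nc1c(C(O)(C(F)(F)F)C(F)(F)F)ccc2ccccc12`; compound 2 `Cc1ccc(C(=O)Nc2c(C(O)(C(F)(F)F)C(F)(F)F)ccc3ccccc23)cc1`; compound 3 `O=C(Nc1c(C(O)(C(F)(F)F)C(F)(F)F)ccc2ccccc12)c1ccco1`.

In an assay on LtK cells with ATP-sensitive inward rectifier potassium channel 11 (Homo sapiens) as the target (a higher number here means that more compound is needed for the effect, a lower number that less compound is needed), compound 2 gives 76 nM, the only number shown. Compound 1 gives > 10000 nM, which is a limit of the assay and not a number. Among the compounds with values here, the one measured step, an at least 130-fold lower number from compound 1 to compound 2 (2.11 log units; beyond the scatter), replaced 1-methylbutyl by 4-methylphenyl. Compound 3 differs from compound 2 by furan-2-yl in place of 4-methylphenyl on a carbonyl carbon, one aromatic ring for another, a smaller change than the measured one, so a modest step is expected: a 2.6-fold higher number from compound 2 to compound 3 (0.42 log units; beyond the scatter). Compound 3 is therefore expected at 200 nM, between 50 nM and 800 nM.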

Compound 3, half-maximal effective concentration: 9 nM
Compound 3: the middle estimate sits 22-fold (1.35 log units) above what was measured; the whole stated range lies above it.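

In this assay, the group on this carbonyl carbon matters even when one aromatic ring replaces another, with an 8.4-fold lower number from compound 2 to compound 3 (0.93 log units; beyond the scatter). Against the chain, the same ring gives an at least 1100-fold lower number from compound 1 to compound 3 (3.04 log units; beyond the scatter). Compound 1 stands at a limit of the assay, so that step is a bound only: the limit of > 10000 nM in this assay, at which 1 of the 3 values shown sits.

From the compounds shown here alone, whether the lower number follows the ring oxygen, the smaller ring or the loss of the methyl stays open. A thiophen-2-yl or an unsubstituted phenyl on the same carbonyl carbon would separate these.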